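The source may report more compounds than this note shows. Statements on the series, on what has been measured and on what is new or still open speak of the compounds shown alone.

The toxicity part of this work has so far placed two compounds on a toxicity assay on Huh-7.5 cells (Homo sapiens) for inhibition, read by MTT assay, with a stated time of 96 h; on this read-out lower numbers stand for higher toxicity in this test and higher numbers for lower toxicity in this test. Compound 1, `CN1CCN(Cc2ccc(NC(=O)c3ccc(OCCCCl)c([N+](=O)[O-])c3)cc2C#N)CC1`, gives a reading of 15500 nM. Compound 2, `CN1CCN(Cc2ccc(NC(=O)c3ccc(OCCCCl)c(Cl)c3)cc2C(F)(F)F)CC1`, gives 4100 nM. On those two numbers compound 2 stands lowest, with compound 1 the nearer and only neighbour at a higher value, a gap that goes beyond the scatter; the two compounds differ in two places, so their values are shown side by side and nothing more is drawn from them.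

Compound 3, `CN1CCN(Cc2ccc(NC(=O)c3ccc(OCCCCl)c([N+](=O)[O-])c3)cc2C(F)(F)F)CC1`, has not yet been measured in this assay. It departs from compound 2 by a single change: nitro in place of chloro on an aromatic carbon. The step from compound 2 to compound 3 is expected to be small, toward a higher number if anywhere, and may well stay within the scatter; it is estimated at a 1.7-fold higher number from compound 2 to compound 3 (0.23 log units; within the scatter). Compound 3 is accordingly expected to give about 7000 nM, within a range from 3000 nM to 17000 nM.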

Compound 3, half-maximal cytotoxic concentration: 6800 nM
Estimate against measurement, compound 3: 1.0-fold (0.01 log units) above, and the stated range covers the measured number.
By their numbers in this assay, from the lowest: compounds 2 and 3 (each within the scatter of the next); then compound 1.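

In this assay, nitro in place of chloro, ortho to a 3-chloropropoxy group, gives a 1.7-fold higher number from compound 2 to compound 3 (0.22 log units; within the scatter), so this read-out does not tell the two groups apart at this position. The gap that could not be interpreted earlier now has a comparison in one place: trifluoromethyl in place of cyano on an aromatic carbon gives a 2.3-fold lower number from compound 1 to compound 3 (0.36 log units; beyond the scatter), a modest step, and the only one of the two that goes beyond the scatter. No measurement at hand bears on why either step has its size.

Still open, going by these compounds, is whether an amine or a carboxylic acid ortho to the 3-chloropropoxy group would read like nitro and chloro, and what a longer chain in place of that 3-chloropropoxy group would do. Whether trifluoromethyl in place of cyano gives a similar step with chloro on the ring also remains open, as only a single such pair is shown.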